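The source may report more compounds than this note shows. Statements on the series, on what has been measured and on what is new or still open speak of the compounds shown alone.

Among the three compounds measured so far, compound 3 `Cc1ccc(NC(=S)NC(=O)c2ccc(OCc3ccccc3F)cc2)cc1-c1nc2ccccc2[nH]1` stands lowest in a functional assay on MGC-803 cells (Homo sapiens) for inhibition, read by MTT assay, with a stated time of 48 h (on this read-out higher numbers stand for weaker inhibition and lower numbers for stronger inhibition), where compound 3 gives 3070 nM. Compound 1 `Cc1ccc(NC(=S)NC(=O)c2ccc(OCc3ccccc3)cc2)cc1-c1nc2ccccc2[nH]1` gives 60700 nM, and compound 2 `Cc1ccc(NC(=S)NC(=O)c2ccc(OCc3cccc(Cl)c3)cc2)cc1-c1nc2ccccc2[nH]1` gives 51300 nM. The step of a 20-fold lower number from compound 1 to compound 3 (1.30 log units; beyond the scatter) is large, as is a 17-fold lower number from compound 2 to compound 3 (1.22 log units; beyond the scatter), whereas a 1.2-fold lower number from compound 1 to compound 2 (0.07 log units; within the scatter) stays within the scatter.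

Compound 4 `Cc1ccc(NC(=S)NC(=O)c2ccc(OCc3cccc(Cl)c3Cl)cc2)cc1-c1nc2ccccc2[nH]1` has not yet been measured. It differs from compound 3 in one place: 2,3-dichlorophenyl in place of 2-fluorophenyl on a saturated chain carbon bound to an oxygen on an aromatic ring. In other words, the (2-fluorobenzyl)oxy group becomes a (2,3-dichlorobenzyl)oxy group. Two of the measured steps bear on this. The fluoro that enters in the step from compound 1 to compound 3 is the one that leaves here, and that step was large. A single chloro entering the same ring, in the step from compound 1 to compound 2, gave no change beyond the scatter. Compound 4 therefore keeps no part of the change that set compound 3 apart, and carries instead a change of the kind that did nothing between compound 1 and compound 2. Within the data shown here, the expected step of an 8.1-fold higher number from compound 3 to compound 4 (0.91 log units; beyond the scatter) is therefore upward, toward weaker inhibition, though the second chloro has no measured precedent and leaves the size uncertain. For compound 4 the estimate in this assay is 25000 nM, expected to fall between 6000 nM and 70000 nM.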

Compound 4, half-maximal inhibitory concentration: > 100000 nM
Compound 4 was reported as a limit; the forecaster's own chance of this, stated with the estimate: 5%; at least 4.0-fold (0.60 log units) between middle value and limit.
By their numbers in this assay, from the lowest: compound 3; then compounds 2 and 1 (each within the scatter of the next). At a limit, above all of these: compound 4.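

Compound 4 in this assay is reported only as a limit, not as a number: the limit of > 100000 nM in this assay, at which 1 of the 4 values shown sits.

The change from the (2-fluorobenzyl)oxy group to the (2,3-dichlorobenzyl)oxy group is large, an at least 32-fold higher number from compound 3 to compound 4 (1.51 log units; beyond the scatter), so a halogen on this ring does not by itself bring the low number of compound 3, and among the four compounds only the 2-fluorobenzyl group gives a number set clearly apart from the rest. The other two comparisons give only floors, an at least 1.9-fold higher number from compound 2 to compound 4 (0.28 log units; that floor lies within the scatter) and an at least 1.6-fold higher number from compound 1 to compound 4 (0.21 log units; that floor lies within the scatter), and both floors lie within the scatter, so the result does not settle whether the 2,3-dichlorobenzyl group truly stands higher than the 3-chloro-substituted and unsubstituted benzyl groups or simply alongside them.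

It remains open whether the low number of compound 3 is particular to fluoro, since only one fluoro compound is shown and a methoxy, a nitrile or an amine on the same ring would help to tell. It also remains open how far the number can fall at this place, as the only step downward shown is the one that brings in that single fluoro.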